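The source may report more compounds than this note shows. Statements on the series, on what has been measured and on what is new or still open speak of the compounds shown alone.

Compound 1 `CSCC[C@H](NC(=O)c1cc2ccccc2cn1)C(=O)OCc1ccccc1`: 39.6%
Compound 2 `O=C(C[C@H](NC(=O)c1cc2ccccc2cn1)C(=O)OCc1ccccc1)OCc1ccccc1`: 37.5%

In a functional assay on the whole organism (CCRF S-180 cells, Mus musculus) for inhibition, in a xenograft, with stated times of 7 days and 24 h, at a dose of 100 umol/kg by the intraperitoneal route (on this read-out higher numbers stand for more inhibition at the one dose given (going by the name of the read-out) and lower numbers for less inhibition), compound 2 stands close to compound 1, the step of a number 2.1 percentage points lower from compound 1 to compound 2 (within the scatter) lying within the scatter. Compound 3 `C[C@H](NC(=O)c1cc2ccccc2cn1)C(=O)OCc1ccccc1` differs from compound 2 by hydrogen in place of benzyloxycarbonyl on a saturated chain carbon, two bonds along the chain from an amide-type nitrogen and a carbonyl carbon. Within the data shown here, the only measured step at that place, a number 2.1 percentage points lower from compound 1 to compound 2 (within the scatter), exchanged one group for another without moving the read-out beyond the scatter, so the step of a number 1.5 percentage points lower from compound 2 to compound 3 (within the scatter) is expected to stay within the scatter as well, with no clear direction. Compound 3 is accordingly estimated at 36%, with a range from 15% to 55%.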

Compound 3, a percentage reported as inhibition, in the whole organism at one dose (the size of the read-out at that dose, not a potency): 40.6%
Estimate against measurement, compound 3: 4.6 percentage points below; low and high end bracket the measured number.
By their numbers in this assay, from the lowest: compounds 2, 1 and 3 (each within the scatter of the next).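

In this assay, putting hydrogen in place of the whole benzyloxycarbonyl on this saturated chain carbon gives a number 3.1 percentage points higher from compound 2 to compound 3 (within the scatter), and putting hydrogen in place of (methylsulfanyl)methyl gives a number 1 percentage points higher from compound 1 to compound 3 (within the scatter). The earlier step had only swapped one group for another, whereas these two remove the group, and at this single dose the read-out still does not separate methyl from either longer chain. No measurement at hand offers an explanation for this flat result.

From the compounds shown here alone, whether an amine or a carboxylic acid at this place would move the read-out beyond the scatter stays open, as does the response at any other dose.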